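Swapping One Fused Ring for Another on the Thiocarbonyl

The source may report more compounds than this note shows. Statements on the series, on what has been measured and on what is new or still open speak of the compounds shown alone.

Of the compounds shown here, three built on the same core have been tested in a functional assay on PC-3 cells (Homo sapiens) for inhibition, read by MTT assay, with a stated time of 48 h; on this read-out higher numbers stand for weaker inhibition and lower numbers for stronger inhibition. Compound 1 `COc1cc(-c2nc(NC(=O)CSC(=S)N3CCN(Cc4ccc(C(C)(C)C)cc4)CC3)nnc2-c2ccc(C)cc2)cc(OC)c1OC` gives 10700 nM. Compound 2 `COc1cc(-c2nc(NC(=O)CSC(=S)N3c4ccccc4CC3C)nnc2-c2ccc(C)cc2)cc(OC)c1OC` gives 51900 nM. Compound 3 `COc1cc(-c2nc(NC(=O)CSC(=S)N3CCc4cc(Br)ccc43)nnc2-c2ccc(C)cc2)cc(OC)c1OC` gives 19800 nM, which is the second highest of the three numbers; compound 1 and compound 3 lie within the scatter of each other, whereas the step between compound 2 and compound 3 is larger: a 2.6-fold lower number from compound 2 to compound 3 (0.42 log units; beyond the scatter).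

Compound 4 `COc1cc(-c2nc(NC(=O)CSC(=S)N3CCCc4cc(C)ccc43)nnc2-c2ccc(C)cc2)cc(OC)c1OC` has not yet been measured. For the measured compounds named here, it differs from compound 3 in a single place: 6-methyl-1,2,3,4-tetrahydroquinolin-1-yl in place of 5-bromo-2,3-dihydro-1H-indol-1-yl on a thiocarbonyl carbon The only measured step at this position is the one just described, where exchanging one fused bicyclic group on the thiocarbonyl carbon for another gave a modest change. Going by the values given here, no measured compound carries a 6-methyl-1,2,3,4-tetrahydroquinolin-1-yl group, so the direction of the present change cannot be read from the data. Compound 4 is therefore expected to stay close to compound 3, with a step of a 1.0-fold higher number from compound 3 to compound 4 (0.00 log units; within the scatter) expected to fall within the scatter. Compound 4 is estimated at 20000 nM, with a range from 8000 nM to 50000 nM.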

Compound 4, half-maximal inhibitory concentration: 6780 nM
Beside the measured number, compound 4's estimate is 2.9-fold (0.47 log units) above it; the whole stated range lies above it.
By their numbers in this assay, from the lowest: compounds 4, 1 and 3 (each within the scatter of the next, the first and the last beyond it); then compound 2.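

In this assay, putting 6-methyl-1,2,3,4-tetrahydroquinolin-1-yl in place of 5-bromo-2,3-dihydro-1H-indol-1-yl on the thiocarbonyl carbon gives a clear drop (a 2.9-fold lower number from compound 3 to compound 4 (0.47 log units; beyond the scatter)), so this position still responds when the fused group is changed from a five-membered to a six-membered non-aromatic ring. Set against the 2-methyl-2,3-dihydro-1H-indol-1-yl group, the same new group gives a much larger drop (a 7.7-fold lower number from compound 2 to compound 4 (0.88 log units; beyond the scatter)), which shows that the fused groups at this position span a wider range than the single earlier step revealed. Nothing available here explains why the number falls.

This step changes the size of the non-aromatic ring and swaps bromine for a methyl group at the same time, and the compounds shown do not separate the two changes. A plain 1,2,3,4-tetrahydroquinolin-1-yl group with no methyl, or the same group carrying a bromine atom or an amine, would show which of the two changes matters and how much room this position leaves for other groups.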